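A few compounds are considered here, and "the series" means these few. Any claim that something is new, unique, unknown or untested is made for them only; others in the source may bear on it.

Working notes on the series in a functional assay on SF-539 cells (Homo sapiens) for inhibition, read by sulforhodamine B assay, with a stated time of 48 h; a lower number here means a stronger inhibitor of growth, a higher number a weaker inhibitor of growth. Of the compounds shown here, three have numbers so far. Compound 1 `O=C(Nc1cccc(-n2cc(-c3ccncc3)c(-c3ccc(Cl)c(O)c3)n2)c1)Nc1ccc(Cl)c(Cl)c1` gives 1340 nM. Compound 2 `COc1cc(-c2nn(-c3cccc(NC(=O)c4ccc(Cl)c(C(F)(F)F)c4)c3)cc2-c2ccncc2)ccc1Cl` gives 4130 nM, and compound 3 `COc1cc(-c2nn(-c3cccc(NC(=O)c4ccccc4)c3)cc2-c2ccncc2)ccc1Cl` gives 387 nM. Compound 1 therefore stands second highest of the three numbers, below compound 2 and above compound 3, with both gaps beyond the scatter.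

Among the compounds with values here, the one step so far between compounds that differ in a single place is an 11-fold lower number from compound 2 to compound 3 (1.03 log units; beyond the scatter), where phenyl replaces 4-chloro-3-(trifluoromethyl)phenyl on a carbonyl carbon; that step is large.

Compound 4 `O=C(Nc1cccc(-n2cc(-c3ccncc3)c(-c3ccc(Cl)c(O)c3)n2)c1)Nc1cccc(C(F)(F)F)c1` is not yet measured. It differs from compound 1 as follows: 3-(trifluoromethyl)phenyl in place of 3,4-dichlorophenyl on an amide-type nitrogen. The change sits on an amide-type nitrogen whose other neighbour is the carbonyl carbon, not on the carbonyl carbon itself as in the step from compound 2 to compound 3, and it exchanges one substituted phenyl for another rather than stripping the substituents. Within the data shown here, no measured pair shows this exchange. The step from compound 2 to compound 3 bears on it only loosely, and the expectation is a step of a 1.0-fold lower number from compound 1 to compound 4 (0.01 log units; within the scatter) in this assay, not beyond the scatter in either direction. Compound 4 is estimated at 1300 nM, with a range of 450 nM to 3800 nM.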

Compound 4, concentration for 50% growth inhibition: 3540 nM
Beside the measured number, compound 4's estimate is 2.7-fold (0.44 log units) below it, and the stated range covers the measured number.
By their numbers in this assay, from the lowest: compound 3; then compound 1; then compounds 4 and 2 (each within the scatter of the next).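

In this assay, within the data shown here, the step of a 2.6-fold higher number from compound 1 to compound 4 (0.42 log units; beyond the scatter) is the first reading of a change on an amide-type nitrogen whose other neighbour is the carbonyl carbon. It shows that this position does not accept one substituted phenyl as freely as another: with 3-(trifluoromethyl)phenyl in place of 3,4-dichlorophenyl, growth inhibition is modestly weaker, even though both groups keep a single aromatic carbon ring and neither adds a hydrogen-bond donor or acceptor. The earlier step of an 11-fold lower number from compound 2 to compound 3 (1.03 log units; beyond the scatter) removes the substituents at a different place, so it could not show this exchange, and no measured property at hand explains the new step.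

Still open, as far as these compounds go, is how an unsubstituted phenyl, or a phenyl carrying an amine or a carboxylic acid, would read on this nitrogen. Also open, from the compounds shown here alone, is whether exchanging 3,4-dichlorophenyl for 3-(trifluoromethyl)phenyl would give a step of similar size with the rest of the molecule changed, so this single pair sets no general rule for the series.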